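The source may hold more compounds than are shown below. What is called first, only, known or untested is meant among the compounds shown, and "the series" means these compounds.

Measured so far:
- compound 1, `CCC(CC)C(=O)Nc1c(C(O)(C(F)(F)F)C(F)(F)F)ccc2ccccc12`: 4340 nM in an assay on LtK cells with ATP-sensitive inward rectifier potassium channel 11 (Homo sapiens) as the target; a higher number here means that more compound is needed for the effect, a lower number that less compound is needed
- compound 2, `CC(C)=CC(=O)Nc1c(C(O)(C(F)(F)F)C(F)(F)F)ccc2ccccc12`: 46 nM
- compound 3, `O=C(Nc1c(C(O)(C(F)(F)F)C(F)(F)F)ccc2ccccc12)c1ccc(C(F)(F)F)cc1`: 160 nM

Compound 3 stands second highest of the three numbers. Its nearest neighbour is compound 2, with a 3.5-fold higher number from compound 2 to compound 3 (0.54 log units; beyond the scatter); the furthest is compound 1, with a 27-fold lower number from compound 1 to compound 3 (1.43 log units; beyond the scatter). The third step in the set, a 94-fold lower number from compound 1 to compound 2 (1.97 log units; beyond the scatter), also points to the branched saturated chain as the least favourable acyl group seen.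

Compound 4, `O=C(Nc1c(C(O)(C(F)(F)F)C(F)(F)F)ccc2ccccc12)c1cccs1`, has not yet been measured. Its change from compound 3 is thiophen-2-yl in place of 4-(trifluoromethyl)phenyl on a carbonyl carbon.

Among the measured compounds shown here, no measured step exchanges one aromatic acyl group for another, so the bearing of the three steps is indirect: both carry the amide and the shared core of compound 3 unchanged, and compound 2 shows that a smaller unsaturated group on the carbonyl carbon can give a lower number than the 4-(trifluoromethyl)phenyl of compound 3. A step of a 1.5-fold lower number from compound 3 to compound 4 (0.16 log units; within the scatter) is therefore expected, likely within or just beyond the scatter, toward a lower number. For compound 4 a value of 110 nM is estimated, with a range from 35 nM to 400 nM.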

Compound 4, half-maximal effective concentration: 12 nM
Compound 4: the middle estimate sits 9.2-fold (0.96 log units) above what was measured; the measured number lies below the stated range.
By their numbers in this assay, from the lowest: compound 4; then compound 2; then compound 3; then compound 1.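

In this assay, among the compounds shown here, the change from 4-(trifluoromethyl)phenyl to thiophen-2-yl is the only exchange of one aromatic acyl group for another, and a 13-fold lower number from compound 3 to compound 4 (1.12 log units; beyond the scatter) shows that the number on this carbonyl carbon depends strongly on which aromatic ring is present. Thiophen-2-yl also outdoes the unsaturated open chain, with a 3.8-fold lower number from compound 2 to compound 4 (0.58 log units; beyond the scatter) as the step, and extends the distance from the branched saturated chain to a 360-fold lower number from compound 1 to compound 4 (2.56 log units; beyond the scatter) so that compound 4 is the lowest of the four, beyond the scatter against each of the others. Nothing available here accounts for these differences.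

The compounds shown do not separate the change of ring from the loss of trifluoromethyl. Unsubstituted phenyl, furan-2-yl and thiophen-3-yl on this carbonyl carbon remain the comparisons that would tell these apart.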